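A Methyl in Place of Methoxy: Expected Cytotoxicity

This account rests on a few compounds, and the source may have more. Where it says the series, first, only, none or still open, it means among the compounds named here.

Compound 1, `COC(=O)CCCNC(=O)CSC1=C(OC)C(=O)c2ccccc2C1=O`: 24500 nM
Compound 2, `COC(=O)[C@@H](NC(=O)CSC1=C(OC)C(=O)c2ccccc2C1=O)C(C)C`: 56000 nM
Compound 3, `COC(=O)[C@H](CC(C)C)NC(=O)CSC1=C(OC)C(=O)c2ccccc2C1=O`: 25500 nM

All three were tested in a functional assay on SAS cells (Homo sapiens) for cytotoxicity, read by MTT assay, with a stated time of 48 h; on this read-out higher numbers stand for weaker inhibition and lower numbers for stronger inhibition. Compound 2 gives the highest number of the three, its steps to the others being a 2.2-fold lower number from compound 2 to compound 3 (0.34 log units; beyond the scatter) and, in the other direction, a 2.3-fold higher number from compound 1 to compound 2 (0.36 log units; beyond the scatter). Compound 4, `COC(=O)[C@@H](NC(=O)CSC1=C(C)C(=O)c2ccccc2C1=O)C(C)C`, differs from compound 2 in one place: methyl in place of methoxy on a double-bonded ring carbon. Among the compounds with values here, every measured step so far changed the group on the amide-type nitrogen, while this change sits on the ring, so no measured step speaks to it directly. With nothing in the data to move the number either way, no step beyond the scatter is expected. Compound 4 is therefore expected to give 56000 nM, within 20000 nM to 150000 nM. The expected step is no change at the digits printed from compound 2 to compound 4 (within the scatter).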

Compound 4, half-maximal inhibitory concentration: 16000 nM
Compound 4: middle estimate off by 3.5-fold (0.54 log units), on the high side, and the stated range ends above it.
By their numbers in this assay, from the lowest: compounds 4, 1 and 3 (each within the scatter of the next); then compound 2.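

The ring carbon is not a silent position: in this assay, methyl in place of methoxy gives a 3.5-fold lower number from compound 2 to compound 4 (0.54 log units; beyond the scatter), a step beyond the scatter. Within the data shown here, earlier steps changed only the group on the amide-type nitrogen, so this is the first sign that a change on the ring also moves the number. Nothing measured here explains the step. On these data alone, whether the same change would give a similar step with the groups on the nitrogen of compound 1 or compound 3 stays open. So does the effect of an ethyl, a chlorine or an amine on this ring carbon.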